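This account rests on a few compounds, and the source may have more. Where it says the series, first, only, none or still open, it means among the compounds named here.

Compound 1 `COc1ccn2nc(C)c(C(=O)NCc3ccc(N4CCC(c5ccc(OC(F)(F)F)cc5)CC4)cc3)c2c1`: > 100000 nM
Compound 2 `Cc1nn2ccc(C(C)C)cc2c1C(=O)NCc1ccc(N2CCC(c3ccc(OC(F)(F)F)cc3)CC2)cc1`: "not determined" (no result reported)
Compound 3 `Cc1nn2ccc(C(C)(C)C)cc2c1C(=O)NCc1ccc(N2CCC(c3ccc(OC(F)(F)F)cc3)CC2)cc1`: "not determined" (no result reported)

Three compounds sharing one core were examined in an ADME assay on Vero cells (Chlorocebus sabaeus) for cytotoxicity, read by CCK-8 assay, with a stated time of 72 h; a lower number here means a stronger inhibitor, a higher number a weaker inhibitor. In this assay compound 1 returns > 100000 nM, which is a limit of the assay and not a number. In this assay compound 2 has the entry "not determined" (no result reported). In this assay compound 3 likewise has the entry "not determined" (no result reported), so compound 3 stands nowhere among the numbers: it has no value of its own. Of the other two entries, that of compound 1 is a limit of the assay, and that of compound 2 carries no number at all. Among the compounds with values here, the only evidence available is the limit of > 100000 nM in this assay, at which 1 of the 3 values shown sits.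

Compound 4 `Cc1nn2ccc(C(F)(F)F)cc2c1C(=O)NCc1ccc(N2CCC(c3ccc(OC(F)(F)F)cc3)CC2)cc1` differs from compound 3 in one place: trifluoromethyl in place of tert-butyl on an aromatic carbon. Within the data shown here, no step between measured compounds exists in this assay, so the size and direction of this change cannot be read from the data; nothing here points to a step beyond the scatter. The expectation for compound 4 rests on the limit seen for compound 1, (the limit of > 100000 nM in this assay, at which 1 of the 3 values shown sits). Compound 4 is expected to give 100000 nM, with a range from 30000 nM to 300000 nM, and most likely a limit rather than a number.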

Compound 4, half-maximal inhibitory concentration: > 100000 nM
Compound 4: a limit, no number; the forecaster's own chance of this, stated with the estimate: 85%; the middle value sits exactly at the limit.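

Compound 1 and compound 4 both return a limit rather than a number in this assay, so no step can be read between them. The compounds shown leave open at what concentration, if any, this series would register a measurable effect in this assay: the limit of > 100000 nM in this assay, at which 2 of the 4 values shown sit.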